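Sulfamoyl for trifluoromethoxy: expectation for compound 4

The compounds below may be only part of what the source reports. "The series", "measured", "known", "first", "only" and "open" are said of these compounds alone.

Compound 1 `O=C1C(Nc2ccc(OC(F)(F)F)cc2)=CC(=O)c2ncncc21` gives 900 nM in a functional assay on PANC-1 cells (Homo sapiens) for cytotoxicity, read by MTT assay, with a stated time of 72 h (on this read-out lower numbers stand for stronger inhibition and higher numbers for weaker inhibition), and holds the lowest number among the three measured compounds. Compound 2 `O=C1C(NCc2ccc(F)cc2)=CC(=O)c2ncncc21` gives 1000 nM in this assay, a value within the scatter of compound 1. The unsubstituted core, compound 3 `O=C1C=CC(=O)c2ncncc21`, gives 18000 nM in this assay, a number beyond the scatter above compound 1.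

Compound 4 `NS(=O)(=O)c1ccc(NC2=CC(=O)c3ncncc3C2=O)cc1` keeps the core and the anilino attachment of compound 1 and differs only in sulfamoyl in place of trifluoromethoxy on an aromatic carbon. Among the measured compounds shown here, no measured pair shows this change, so no step size is known for it. The step of a 1.7-fold higher number from compound 1 to compound 4 (0.22 log units; within the scatter) from compound 1 is expected to be small, none beyond the scatter or a modest move toward higher numbers. Compound 4 is estimated at 1500 nM, with a range of 500 nM to 5000 nM.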

Compound 4, half-maximal inhibitory concentration: > 10000 nM
Compound 4: a limit, no number; the forecaster's own chance of this, stated with the estimate: 5%; at least 6.6-fold (0.82 log units) between middle value and limit.
By their numbers in this assay, from the lowest: compounds 1 and 2 (each within the scatter of the next); then compound 3.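

In this assay compound 4 gives > 10000 nM, which is a limit of the assay and not a number. The group on this aromatic carbon can therefore move the read-out strongly: sulfamoyl in place of trifluoromethoxy gives an at least 11-fold higher number from compound 1 to compound 4 (1.04 log units; beyond the scatter), the first step read at this place in the series. The full size of that step cannot be read: the limit of > 10000 nM in this assay, at which 1 of the 4 values shown sits.

Still open, going by these compounds, is whether an amine, a carboxylic acid or a methoxy group on this carbon would read close to compound 1 or close to compound 4.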